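A hydroxyl moved around the phenyl ring of compound 2

A few compounds are considered here, and "the series" means these few. Any claim that something is new, unique, unknown or untested is made for them only; others in the source may bear on it.

Compound 1 `Clc1cccc(-c2nc(N3CCCCC3)c3nc[nH]c3n2)c1`, compound 2 `Oc1cccc(-c2nc(N3CCCCC3)c3nc[nH]c3n2)c1` and compound 3 `CN1CCN(c2nc(-c3cccc(O)c3)nc3[nH]cnc23)CC1` share one core and were all tested in an assay on cells for displacement of a labelled ligand from adenosine receptor A1 (Homo sapiens), read by scintillation counting and radioligand binding, with a stated time of 60 min, tested at 10 uM; a higher number here means more inhibition at the concentration tested (going by the name of the read-out), a lower number less inhibition. In this assay compound 1 gives > 80%, which is a limit of the assay and not a number. Compound 2 gives > 80%, again a limit. Compound 3 gives > 80%, also a limit. The step that the two limits leave unreadable from compound 1 to compound 2 cannot be read in size, nor can a step that the two limits leave unreadable from compound 2 to compound 3, since all three values sit at the limit of > 80% in this assay, at which 3 of the 3 values shown sit. Compound 2 therefore stands at the limit of this assay, with no number that would set it apart from its neighbours.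

Compound 4 `Oc1ccc(-c2nc(N3CCCCC3)c3nc[nH]c3n2)cc1` differs from compound 2 by 4-hydroxyphenyl in place of 3-hydroxyphenyl on an aromatic carbon. For the measured compounds named here, no measured step bears directly on this change, and the two steps that exist are unreadable. The expectation rests only on the three limits, so compound 4 is expected to stay at the limit as well. Compound 4 is estimated at 85%, with a range from 60% to 100%. For compound 4 this estimate means an expected step that the limit leaves unreadable from compound 2 to compound 4.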

Compound 4, a percentage reported as inhibition, at one concentration (the size of the read-out at that concentration, not a potency): > 80%
Compound 4 ended at the assay's limit; the forecaster's own chance of this, stated with the estimate: 70%; the middle value does not contradict the limit.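

No step from compound 2 or compound 1 to compound 4 can be read in this assay, because each value there is a limit and not a number: the limit of > 80% in this assay, at which 4 of the 4 values shown sit.

The compounds shown leave open whether 4-hydroxyphenyl and 3-hydroxyphenyl differ at all in this assay.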